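Replacing the 4-bromophenyl of compound 1

The source may hold more compounds than are shown below. What is called first, only, known or untested is meant among the compounds shown, and "the series" means these compounds.

Measured in a functional assay on SMMC-7721 cells (Homo sapiens) for cytotoxicity, read by MTT assay, with a stated time of 72 h (a higher number here means a weaker inhibitor, a lower number a stronger inhibitor), so far:
compound 1 `O=C1C(=Cc2ccc(Br)cc2)C(=O)N(c2ccc(Cl)cc2)N1c1ccc(Cl)cc1` gives 16600 nM
compound 2 `COc1cc(C=C2C(=O)N(c3ccc(Cl)cc3)N(c3ccc(Cl)cc3)C2=O)ccc1O` gives 64900 nM
compound 3 `CC(=C1C(=O)N(c2ccc(Cl)cc2)N(c2ccc(Cl)cc2)C1=O)c1ccc(O)cc1` gives 57000 nM

Compound 1 has the lowest number of the three, and compound 2 and compound 3 both lie higher by more than the scatter. The next compound to be measured is compound 4 `COc1ccc(C=C2C(=O)N(c3ccc(Cl)cc3)N(c3ccc(Cl)cc3)C2=O)cc1OC`. Its difference from compound 1 is 3,4-dimethoxyphenyl in place of 4-bromophenyl on a double-bonded chain carbon bound to a double-bonded ring carbon.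

Within the data shown here, one measured step bears directly on this change: a 3.9-fold higher number from compound 1 to compound 2 (0.59 log units; beyond the scatter). That step replaces the same 4-bromophenyl at the same place, and the entering group again carries a methoxy group. Among the measured compounds shown here, compound 3 differs from compound 1 in more than one place, so it offers no clean step, though its value also lies higher. On the evidence of this single step, a rise of similar or slightly smaller size is expected in this assay, probably beyond the scatter. The expected change is a 2.7-fold higher number from compound 1 to compound 4 (0.43 log units; beyond the scatter). For compound 4 the estimated value is 45000 nM, with an expected range from 20000 nM to 100000 nM.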

Compound 4, half-maximal inhibitory concentration: > 128000 nM
Compound 4 ended at the assay's limit; the forecaster's own chance of this, stated with the estimate: 10%; at least 2.8-fold (0.45 log units) between middle value and limit.
By their numbers in this assay, from the lowest: compound 1; then compounds 3 and 2 (each within the scatter of the next). At a limit, above all of these: compound 4.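

In this assay compound 4 gives > 128000 nM, which is a limit of the assay and not a number. At this place on a double-bonded chain carbon bound to a double-bonded ring carbon, 3,4-dimethoxyphenyl in place of 4-bromophenyl gives an at least 7.7-fold higher number from compound 1 to compound 4 (0.88 log units; beyond the scatter), so a second replacement of the 4-bromophenyl moves in the same direction as a 3.9-fold higher number from compound 1 to compound 2 (0.59 log units; beyond the scatter). Methyl in place of hydrogen on an oxygen on an aromatic ring gives an at least 1.9-fold higher number from compound 2 to compound 4 (0.29 log units; that floor lies within the scatter), so no order between these two compounds can be stated.

Both replacements remove the bromine and bring in oxygen-bearing groups together, leaving open which of these changes goes with the higher numbers. A 4-chlorophenyl, or a phenyl carrying an amine or a carboxylic acid, at this place would test this further.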